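Adding a methoxy to compound 1

A few compounds are considered here, and "the series" means these few. Any claim that something is new, unique, unknown or untested is made for them only; others in the source may bear on it.

compound 1 `Nc1ccc(-c2nc3ccccc3s2)c(I)c1`: < 0.1 nM
compound 2 `Nc1ccc(-c2nc3ccccc3s2)c(Cl)c1`: < 0.1 nM

In a functional assay on MDA-MB-468 cells (Homo sapiens) for inhibition (a higher number here means a weaker inhibitor, a lower number a stronger inhibitor), compound 1 gives < 0.1 nM, which is a limit and not a number. Compound 2 gives < 0.1 nM, also a limit. The data therefore show only (the limit of < 0.1 nM in this assay, at which 2 of the 2 values shown sit), and compound 1 cannot be placed more exactly.

Compound 3 `COc1ccc2nc(-c3ccc(N)cc3I)sc2c1` differs from compound 1 by methoxy in place of hydrogen on an aromatic carbon. Among the compounds with values here, the one measured step, a step that the two limits leave unreadable from compound 1 to compound 2, is a different change, chloro in place of iodo on an aromatic carbon, and it gives no size to carry over. Within the data shown here, no measured step covers the methoxy, so the expectation is loose: a modest move towards weaker inhibition in this assay, or none that can be read. The estimated step is an at least 2.0-fold higher number from compound 1 to compound 3 (0.30 log units; that floor lies within the scatter). For compound 3 the expected value is 0.2 nM, with an estimated range of 0.02 nM to 5 nM.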

Compound 3, half-maximal inhibitory concentration: < 0.1 nM
Compound 3 gave a limit, no number (the forecaster's own chance of this, stated with the estimate: 40%); middle value at least 2.0-fold (0.30 log units) from the limit.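

Within the data shown here, compound 3 and compound 1 both give only a limit in this assay, so no step between them can be read: the limit of < 0.1 nM in this assay, at which 3 of the 3 values shown sit. The compounds shown leave open how compound 1, compound 2 and compound 3 rank, and whether methoxy in place of hydrogen changes inhibition at all.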